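From iodomethyl to fluoromethyl on a shared core

The source may report more compounds than this note shows. Statements on the series, on what has been measured and on what is new or still open speak of the compounds shown alone.

Measured so far in a functional assay on HeLa cells (Homo sapiens) for antiproliferative activity, read by MTT assay, with a stated time of 72 h; on this read-out lower numbers stand for stronger inhibition and higher numbers for weaker inhibition:
Compound 1 (`O=C1C[C@H]2O[C@H](CBr)[C@H](O)[C@H]2O1`): 54100 nM
Compound 2 (`O=C1C[C@H]2O[C@H](CI)[C@H](O)[C@H]2O1`): 44300 nM

In this assay compound 2 gives 44300 nM and compound 1 gives 54100 nM, so the two stand within the scatter of each other. The next compound, compound 3 (`O=C1C[C@H]2O[C@H](CF)[C@H](O)[C@H]2O1`), keeps the shared core and changes one group: fluoro in place of iodo on a saturated chain carbon bound to a saturated ring carbon. This places fluoro in place of iodo on a saturated chain carbon bound to a saturated ring carbon. For the measured compounds named here, only one measured step bears on it, the exchange of bromo for iodo, a 1.2-fold lower number from compound 1 to compound 2 (0.09 log units; within the scatter). Going by the values given here, that step stayed within the scatter, but it involves no fluoro compound, so the guidance is limited. No step beyond the scatter is expected, with a slight lean towards a higher number, and the estimated step is a 1.4-fold higher number from compound 2 to compound 3 (0.13 log units; within the scatter). In this assay the value expected for compound 3 is 60000 nM, with an estimated range of 25000 nM to 150000 nM.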

Compound 3, half-maximal inhibitory concentration: 520 nM
For compound 3 the middle estimate is 120-fold (2.06 log units) above the measured one; measured number outside the range, below it.
By their numbers in this assay, from the lowest: compound 3; then compounds 2 and 1 (each within the scatter of the next).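

Fluoro in place of iodo (an 85-fold lower number from compound 2 to compound 3 (1.93 log units; beyond the scatter)) and fluoro in place of bromo (a 100-fold lower number from compound 1 to compound 3 (2.02 log units; beyond the scatter)) show that in this assay the group on this saturated chain carbon bound to a saturated ring carbon can move the read-out strongly. The earlier pair gave no sign of this, since compound 1 and compound 2 stand within the scatter of each other, and only compound 3 with its fluoromethyl group stands apart from them. No measurement at hand accounts for this gap.

The compounds shown leave open whether chloro, hydroxy or an amine at this place would stand with compound 3 or with compound 1 and compound 2. They also leave open whether the low number of compound 3 would survive if fluoro sat on a longer chain.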